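A 2-chlorophenyl in place of carbamoyl

A few compounds are considered here, and "the series" means these few. Any claim that something is new, unique, unknown or untested is made for them only; others in the source may bear on it.

compound 1 `CCOC(=O)c1c(C)nc(-c2cccc(C#N)c2)n1OC`: 9130 nM
compound 2 `CCOC(=O)c1[nH]c(-c2cccc(C#N)c2)nc1C`: > 30000 nM, a limit
compound 3 `CCOC(=O)c1c(C)nc(-c2cccc(C#N)c2)n1OCC(N)=O`: > 30000 nM, a limit

All three were tested in a functional assay on a cell-free system (plasma, Oryctolagus cuniculus) for inhibition, with stated times of 5 min, 1 min and 6 min; a higher number here means a weaker inhibitor, a lower number a stronger inhibitor. Compound 3 stands at a limit, > 30000 nM, and not at a number.

Compound 4 `CCOC(=O)c1c(C)nc(-c2cccc(C#N)c2)n1OCc1ccccc1Cl` has 2-chlorophenyl in place of carbamoyl on a saturated chain carbon bound to an oxygen on an aromatic ring.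

Within the data shown here, two measured steps bear on this. Carbamoyl in place of hydrogen gave an at least 3.2-fold higher number from compound 1 to compound 3 (0.51 log units; beyond the scatter). Hydrogen in place of methoxy gave an at least 3.2-fold higher number from compound 1 to compound 2 (0.51 log units; beyond the scatter).

Compound 4 lacks that carbamoyl, so a move back towards compound 1 at 9130 nM is expected. The expected step is an at least 4.2-fold lower number from compound 3 to compound 4 (0.63 log units; beyond the scatter). Compound 4 is estimated at 7000 nM, with an expected range of 1500 nM to 30000 nM.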

Compound 4, half-maximal inhibitory concentration: 8710 nM
For compound 4 the middle estimate is 1.2-fold (0.09 log units) below the measured one; the measured number falls inside the stated range.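

Replacing the carbamoyl with 2-chlorophenyl gives an at least 3.4-fold lower number from compound 3 to compound 4 (0.53 log units; beyond the scatter), and (2-chlorobenzyl)oxy in place of hydrogen on the aromatic nitrogen gives an at least 3.4-fold lower number from compound 2 to compound 4 (0.53 log units; beyond the scatter). Compound 2 and compound 3 each stand at a limit, not a number: the limit of > 30000 nM in this assay, at which 2 of the 4 values shown sit. 2-Chlorophenyl in place of hydrogen on the chain carbon gives a 1.0-fold lower number from compound 1 to compound 4 (0.02 log units; within the scatter), so this position accepts the ring and compound 1 and compound 4 stand level.

On these data alone, whether an amine, a carboxylic acid or a longer chain at this position would read differently stays open. As far as these compounds go, how far compound 2 and compound 3 lie past their limit also stays open.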